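This account rests on a few compounds, and the source may have more. Where it says the series, first, only, none or still open, it means among the compounds named here.

In an ADME assay for permeability, read by HPLC, using PAMPA, with a stated time of 5 h, tested at 10 uM (on this read-out higher numbers stand for higher permeability and lower numbers for lower permeability), compound 1 (`O=C(NCCN1CCCC1)c1cc(NCCC2CCOCC2)nc2ccc(Cl)cc12`) gives 48 nm/s and compound 2 (`O=C(NCCN1CCCC1)c1cc(-c2ccc(S(=O)(=O)N3CCOCC3)cc2)nc2ccc(F)cc12`) gives 29 nm/s. Among the compounds with values here, these two values lie within the scatter of each other, so compound 2 stands level with the only other measured compound. Compound 3 (`O=C(NCCN1CCCC1)c1cc(-c2ccc(CN3CCCC3=O)cc2)nc2ccc(F)cc12`) has not yet been measured. It carries (2-oxopyrrolidin-1-yl)methyl in place of (morpholin-4-yl)sulfonyl on an aromatic carbon, para to a large group: (2-oxopyrrolidin-1-yl)methyl in place of (morpholin-4-yl)sulfonyl on an aromatic carbon. Within the data shown here, no measured pair differs in one place only, so the data give no direct guide to this exchange. Compound 1 and compound 2 differ in more than one place, yet their values stay within the scatter, and that is the only basis for expecting a modest effect. The estimated change in this assay is small and slightly upward, a 1.2-fold higher number from compound 2 to compound 3 (0.09 log units; within the scatter), and it is expected to stay within the scatter. Compound 3 is estimated at 36 nm/s, with an expected range of 14 nm/s to 90 nm/s.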

Compound 3, apparent permeability in the ADME assay: 49 nm/s
Compound 3: the middle estimate sits 1.4-fold (0.13 log units) below what was measured; measured number inside the range.
By their numbers in the ADME assay, from the lowest: compounds 2, 1 and 3 (each within the scatter of the next).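

Within the data shown here, this step is the first single-place comparison. In the ADME assay, (2-oxopyrrolidin-1-yl)methyl in place of (morpholin-4-yl)sulfonyl gives a 1.7-fold higher number from compound 2 to compound 3 (0.23 log units; within the scatter), so the two groups stand level on this read-out despite their different counts of heavy atoms and hydrogen-bond acceptors. In a physicochemical assay for solubility, read by nephelometry, measured as kinetic solubility (a higher number here means a more soluble compound, a lower number a less soluble compound), the same exchange gives an at least 1.9-fold higher number from compound 2 to compound 3 (0.29 log units; that floor lies within the scatter). In the physicochemical assay compound 2 gives 109000 nM as a measured number. As far as these compounds go, in the physicochemical assay compound 3 gives > 217000 nM as a limit of the assay, so the true size of this step stays unknown: the limit of > 217000 nM in the physicochemical assay, at which 1 of the 2 values shown sits.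

From the compounds shown here alone, it remains open how an amine such as piperidin-1-ylmethyl or a carboxylic acid on this aromatic carbon would read in either assay. With a single step at this place, no trend across groups can be drawn.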